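The source may hold more compounds than are shown below. What is called first, only, known or untested is meant among the compounds shown, and "the series" means these compounds.

In a functional assay on MDA-MB-231 cells (Homo sapiens) for inhibition, read by MTT assay, with a stated time of 72 h (on this read-out higher numbers stand for weaker inhibition and lower numbers for stronger inhibition), compound 1 (`Nc1ncnc2c1c(-c1cnc3[nH]ccc3c1)nn2CCCCCCCCC(=O)NO`) gives 11000 nM. Compound 3 (`Nc1nc2cc(-c3nn(CCCCC(=O)NO)c4ncnc(N)c34)ccc2o1`) gives 21200 nM, within the scatter of compound 1. Compound 2 (`Nc1nc2cc(-c3nn(CCCCCCCCCC(=O)NO)c4ncnc(N)c34)ccc2o1`) reads > 50000 nM, which is a limit and not a number.

Unmeasured compound 4 (`Nc1ncnc2c1c(-c1cnc3[nH]ccc3c1)nn2CCCC(=O)NO`) differs from compound 1 by a shorter chain: hydroxycarbamoyl in place of 5-(hydroxycarbamoyl)pentyl on a saturated chain carbon, three bonds along the chain from an aromatic nitrogen. Among the measured compounds shown here, the only measured step bearing on this is the same replacement on another core, four bonds along the chain from an aromatic nitrogen: an at least 2.3-fold lower number from compound 2 to compound 3 (0.37 log units; beyond the scatter). Compound 2 is a limit, so that step gives a minimum size only. A modest move to a lower number in this assay is therefore expected, resting on this single precedent. The expected change is a 1.6-fold lower number from compound 1 to compound 4 (0.20 log units; within the scatter). For compound 4 the estimate is 7000 nM, with an expected range of 2000 nM to 30000 nM.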

Compound 4, half-maximal inhibitory concentration: > 150000 nM
Compound 4 was reported as a limit (the forecaster's own chance of this, stated with the estimate: 12%); middle value at least 21-fold (1.33 log units) from the limit.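

Replacing 5-(hydroxycarbamoyl)pentyl with hydroxycarbamoyl at this place gives an at least 13-fold higher number from compound 1 to compound 4 (1.13 log units; beyond the scatter) in this assay. Compound 4 reads > 150000 nM, which is a limit and not a number. The chain shortening therefore does not carry over between cores, and its direction reverses: the same change on two cores in this assay, an at least 2.3-fold lower number (0.37 log units; beyond the scatter) from compound 2 to compound 3 and an at least 13-fold higher number (1.13 log units; beyond the scatter) from compound 1 to compound 4, at least 32-fold (1.50 log units) apart, beyond the scatter of two such steps

The compounds shown leave open how a chain of intermediate length on the core of compound 1 would read, and so where the loss sets in. On these data alone, how a carboxylic acid in place of hydroxycarbamoyl would read on either core also remains open.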